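Phenyl in place of 4-methoxyphenyl on the amide side

A few compounds are considered here, and "the series" means these few. Any claim that something is new, unique, unknown or untested is made for them only; others in the source may bear on it.

Compound 2 `COc1ccc(NC(=O)/C=C/c2coc3cc(O)ccc3c2=O)cc1` carries a free hydroxyl on the shared core and a methoxy on the amide-side ring. In a functional assay on L02 cells (Homo sapiens) for inhibition, read by MTT assay, with a stated time of 48 h (on this read-out higher numbers stand for weaker inhibition and lower numbers for stronger inhibition), compound 2 gives > 200000 nM, which is a limit of the assay and not a number. The two neighbours stand no differently. Compound 1 `COc1ccc(NC(=O)/C=C/c2coc3cc(OC)ccc3c2=O)cc1`, the methyl ether of the core hydroxyl, gives in this assay > 200000 nM, again only a limit. Compound 3 `COc1ccc2c(=O)c(/C=C/C(=O)Nc3ccc(Cl)cc3)coc2c1`, with chloro in place of methoxy on the amide-side ring, gives in this assay > 200000 nM, also a limit. Neither step can therefore be sized: a step that the two limits leave unreadable from compound 1 to compound 2 and a step that the two limits leave unreadable from compound 1 to compound 3 stay unreadable because of the limit of > 200000 nM in this assay, at which 3 of the 3 values shown sit.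

Compound 4 `O=C(/C=C/c1coc2cc(O)ccc2c1=O)Nc1ccccc1` is the next member of the set. Against compound 2 the change is hydrogen in place of methoxy on an aromatic carbon; cut one bond further out it reads 4-methoxyphenyl to phenyl. For the measured compounds named here, the only measured step at that ring, from compound 1 to compound 3, gave no readable size, and the core-hydroxyl step gave none either, so no direction can be drawn from the series. Going by the values given here, with every value so far sitting at the limit, the expected step is a step that the limit leaves unreadable from compound 2 to compound 4, meaning nothing beyond the scatter. Compound 4 is therefore expected at about 250000 nM, most likely reported again as a limit, with a range from 80000 nM to 800000 nM.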

Compound 4, half-maximal inhibitory concentration: > 200000 nM
Compound 4 gave a limit, no number; the forecaster's own chance of this, stated with the estimate: 85%; the middle value lies beyond the limit too.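

No new step can be read between compound 2 and compound 4, where 4-methoxyphenyl gives way to phenyl, because both stand at a limit and not at a number: the limit of > 200000 nM in this assay, at which 4 of the 4 values shown sit.

The compounds shown leave open whether any change on the amide-side ring or at the core hydroxyl shifts the read-out in this assay at all.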